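The source may report more compounds than this note shows. Statements on the series, on what has been measured and on what is new or still open speak of the compounds shown alone.

Measured so far:

Compound 1 `C[C@H](NC(=O)C(c1cccnc1)N(C(=O)c1ccco1)c1ccc(-n2cccc2)cc1)c1ccccc1`: in a toxicity assay on Vero C1008 cells (Chlorocebus sabaeus) for cytotoxicity, read by neutral red uptake, with a stated time of 5 days (on this read-out lower numbers stand for higher toxicity in this test and higher numbers for lower toxicity in this test), compound 1 gives > 200000 nM, a limit of the test and not a number.
Compound 2 `C[C@H](NC(=O)C(c1cccnc1)N(C(=O)c1ccco1)c1ccc(-c2ccccc2)cc1)c1ccccc1`: in this assay compound 2 gives > 200000 nM, again a limit.
Compound 3 `C[C@H](NC(=O)C(c1cccnc1)N(C(=O)c1ccno1)c1ccc(-c2ccccc2)cc1)c1ccccc1`: in this assay compound 3 gives > 200000 nM, also a limit.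

Compound 2 therefore stands at the upper edge of what this assay can report; all three measured compounds sit together at the limit of > 200000 nM in this assay, at which 3 of the 3 values shown sit, so no order among them can be read. The step that the two limits leave unreadable from compound 1 to compound 2 and the step that the two limits leave unreadable from compound 2 to compound 3 are both of unreadable size for the same reason, and neither touches the part of the molecule that changes next.

Compound 4 `O=C(NC1CCCC1)C(c1cccnc1)N(C(=O)c1ccco1)c1ccc(-c2ccccc2)cc1` differs from compound 2 by cyclopentyl in place of 1-phenylethyl on an amide-type nitrogen. Going by the values given here, no measured step bears on this position, so the only guide is that every compound of the series so far, whatever its aromatic substituents, has stayed at the limit. Compound 4 is expected to stay there as well, giving an estimated step that the limit leaves unreadable from compound 2 to compound 4 that is not expected to be readable beyond the scatter. For compound 4 the estimate in this assay is 250000 nM, within a range from 100000 nM to 600000 nM, most probably reported again as a limit only.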

Compound 4, half-maximal cytotoxic concentration: > 200000 nM
Compound 4: a limit, no number (the forecaster's own chance of this, stated with the estimate: 85%); the middle value is on the limit's open side.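

In this assay compound 4 gives > 200000 nM as a limit and not a number. Compound 2 and compound 4 therefore yield no readable step, and the series stays at one edge of the test: the limit of > 200000 nM in this assay, at which 4 of the 4 values shown sit.

The compounds shown leave open at what concentration any of them becomes toxic to these cells, and whether 1-phenylethyl and cyclopentyl differ there.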